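Trading the Ring for an Open Chain

This account rests on a few compounds, and the source may have more. Where it says the series, first, only, none or still open, it means among the compounds named here.

Compound 1 `O=c1cc(-c2ccccc2)oc2ccc(OCCCN3CCC(O)CC3)cc12` and compound 2 `COc1ccc(-c2cc(=O)c3cc(OCCCCCCN4CCC(O)CC4)ccc3o2)cc1` have both been examined in an assay on isolated protein (Cavia porcellus) with Sigma non-opioid intracellular receptor 1 (Homo sapiens) as the target, read by radioligand binding; on this read-out higher numbers stand for weaker inhibition and lower numbers for stronger inhibition. Compound 1 gives 130 nM in this assay, and compound 2 gives 254 nM; the two numbers lie within the usual scatter of each other, so neither compound can be placed ahead of the other. Compound 3 `NCCCCCCOc1ccc2oc(-c3ccccc3)cc(=O)c2c1` has not yet been run in this assay. It departs from compound 1 in a single place: 3-aminopropyl in place of 4-hydroxypiperidin-1-yl on a saturated chain carbon, three bonds along the chain from an oxygen on an aromatic ring. The saturated ring that leaves takes its hydroxyl with it, and the short chain that enters ends in a free amine. Among the compounds with values here, no measured pair shows a change of this kind, so there is no comparable step to lean on. The author expects the step of a 4.2-fold higher number from compound 1 to compound 3 (0.63 log units; beyond the scatter) to run toward weaker inhibition, somewhat beyond the scatter. Compound 3 is estimated at 550 nM, within a range from 150 nM to 2500 nM.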

Compound 3, half-maximal inhibitory concentration: 2100 nM
Compound 3: the middle estimate sits 3.8-fold (0.58 log units) below what was measured; the range from low to high includes it.
By their numbers in this assay, from the lowest: compounds 1 and 2 (each within the scatter of the next); then compound 3.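

In this assay, within the data shown here, 3-aminopropyl in place of 4-hydroxypiperidin-1-yl gives a 16-fold higher number from compound 1 to compound 3 (1.21 log units; beyond the scatter) and is the first step here that can be read between compounds differing in one place. It shows that this place on the saturated chain, three bonds along from an oxygen on an aromatic ring, is not indifferent to the change: the open chain ending in a free amine runs clearly toward weaker inhibition than the saturated ring with its hydroxyl. Nothing at hand explains why the number moves this far.

The ring and the hydroxyl leave together, so the compounds shown cannot separate their shares in the step; piperidin-1-yl without the hydroxyl would bear on that. From the compounds shown here alone, how a dimethylamino group or a carboxylic acid would fare at the end of the same chain also stays open.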